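Phenyl for Methyl on the Anilide of Compound 3

A few compounds are considered here, and "the series" means these few. Any claim that something is new, unique, unknown or untested is made for them only; others in the source may bear on it.

Of the compounds shown here, three have been measured in an assay on isolated protein for inhibition of Rho-associated protein kinase 2 (Homo sapiens), read by scintillation counting, radiometric assay and 33P incorporation, with a stated time of 40 min, in the presence of a further agent that is not named here; a lower number here means a stronger inhibitor, a higher number a weaker inhibitor. Compound 1 `COc1cc(OCC(=O)Nc2cccc(NC(=O)c3ccc(N(C)C)cc3)c2)ccc1C=O` gives 306 nM. Compound 2 `COc1ccc(OCC(=O)Nc2cccc(NC(=O)c3ccc(N(C)C)cc3)c2)cc1OC` reaches only the limit of the assay, > 10000 nM, and the limit of > 10000 nM in this assay, at which 1 of the 3 values shown sits, is all that this value can tell. Between them lies an at least 32-fold higher number from compound 1 to compound 2 (1.51 log units; beyond the scatter). Compound 3 `CC(=O)Nc1cccc(NC(=O)COc2ccc3c(=O)ccoc3c2)c1` gives 136 nM, the lowest of the two numbers that are not limits, with compound 1 standing above it by a gap beyond the scatter.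

Compound 4 `O=C(COc1ccc2c(=O)ccoc2c1)Nc1cccc(NC(=O)c2ccccc2)c1` differs from compound 3 by phenyl in place of methyl on a carbonyl carbon. For the measured compounds named here, the only measured step, from compound 1 to compound 2, concerns the other end of the shared core and does not bear on this change. Compound 1, which carries a benzamide-type group at this position, gives a value somewhat higher than compound 3, but the two also differ at the ether end, so that comparison is not clean. Compound 4 is therefore expected to show no step beyond the scatter, a 1.2-fold higher number from compound 3 to compound 4 (0.07 log units; within the scatter), in this assay. Compound 4 is estimated at 160 nM, between 45 nM and 600 nM.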

Compound 4, half-maximal inhibitory concentration: 16 nM
Compound 4: middle estimate off by 10-fold (1.00 log units), on the high side; measured number below the stated range.
By their numbers in this assay, from the lowest: compound 4; then compound 3; then compound 1. At a limit, above all of these: compound 2.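

For the compounds shown here, changing acetyl to benzoyl is not a neutral exchange in this assay: it gives an 8.5-fold lower number from compound 3 to compound 4 (0.93 log units; beyond the scatter) and is the first measured step at the anilide end of the shared core. Going by these compounds alone, the only earlier step lay at the other end, so this position now proves responsive as well, and a phenyl on this carbonyl carbon is tolerated in place of methyl with a lower number as the outcome. No measured property at hand bears on this step, and its cause stays unexplained.

As far as these compounds go, whether the phenyl ring itself matters or any larger group would do stays open, and a cyclohexyl on the same carbonyl carbon would be needed to tell these apart. Also open, from the compounds shown here alone, is how an amine or a carboxylic acid on that phenyl would alter the number on the core of compound 4.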